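The source may report more compounds than this note shows. Statements on the series, on what has been measured and on what is new or still open speak of the compounds shown alone.

Measured in a functional assay on CEM-CCRF cells for antagonist activity at C-X-C chemokine receptor type 4 (Homo sapiens), read by calcium flux; a higher number here means a weaker inhibitor, a lower number a stronger inhibitor:

- compound 1, `NCc1cc(F)ccc1CN(Cc1nc2ccccc2[nH]1)C1CCCc2cccnc21`: 219 nM
- compound 2, `NCc1ccc(CN(Cc2nc3ccccc3[nH]2)C2CCCc3cccnc32)c(CN)c1`: 10 nM
- compound 3, `COC(=O)c1ccc(CN(Cc2nc3ccccc3[nH]2)C2CCCc3cccnc32)c(CN)c1`: 39 nM

Compound 1 gives the highest number of the three in this assay; its nearest neighbour is compound 3, a modest step below, and the furthest is compound 2, a large step below.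

Compound 4, `NCc1cc(C(N)=O)ccc1CN(Cc1nc2ccccc2[nH]1)C1CCCc2cccnc21`, differs from compound 1 in one place: carbamoyl in place of fluoro on an aromatic carbon

Two measured steps start from the same fluoro on the same position of compound 1. Replacing it by aminomethyl gave a 22-fold lower number from compound 1 to compound 2 (1.34 log units; beyond the scatter). Replacing it by methoxycarbonyl gave a 5.6-fold lower number from compound 1 to compound 3 (0.75 log units; beyond the scatter). Between those two entering groups, a 3.9-fold higher number from compound 2 to compound 3 (0.59 log units; beyond the scatter). Both replacements lowered the number beyond the scatter, so a lowering is expected for carbamoyl as well; the available steps give no way to decide whether it lands nearer the aminomethyl or the methoxycarbonyl outcome, so the expectation sits between them. For compound 4 the expected step is a 6.3-fold lower number from compound 1 to compound 4 (0.80 log units; beyond the scatter). Compound 4 is therefore estimated at 35 nM, with a range from 10 nM to 110 nM.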

Compound 4, half-maximal inhibitory concentration: 15 nM
For compound 4 the middle estimate is 2.3-fold (0.37 log units) above the measured one; low and high end bracket the measured number.
By their numbers in this assay, from the lowest: compounds 2 and 4 (each within the scatter of the next); then compound 3; then compound 1.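

Working notes: in this assay, carbamoyl at this position, para to a large group, gives a 15-fold lower number from compound 1 to compound 4 (1.16 log units; beyond the scatter), so a large step here does not require aminomethyl as the entering group, and the step of a 1.5-fold higher number from compound 2 to compound 4 (0.18 log units; within the scatter) leaves those two groups unseparated. The carbonyl alone does not set the outcome: amino in place of methoxy on the carbonyl carbon gives a 2.6-fold lower number from compound 3 to compound 4 (0.41 log units; beyond the scatter), a modest step beyond the scatter. Nothing available explains why amino and methoxy differ on this carbonyl carbon.

Still open, on these data alone, is how a carboxylic acid, a nitrile or a longer aminoalkyl chain would compare at this position. As far as these compounds go, it is also open whether a methyl group on the amide nitrogen would retain the level of compound 4.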